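The compounds below may be only part of what the source reports. "The series", "measured", "known", "first", "only" and "open" are said of these compounds alone.

Working notes on the thiosemicarbazide-linked series.

Two members have been measured in a functional assay on MGC-803 cells (Homo sapiens) for cytotoxicity, read by MTT assay, with a stated time of 72 h; on this read-out lower numbers stand for stronger inhibition and higher numbers for weaker inhibition. Compound 1 `COc1cc2ncnc(NNC(=S)NC(=O)c3ccc(Cl)cc3)c2cc1OC` carries two methoxy groups on the shared core and a 4-chlorophenyl on the carbonyl; in this assay compound 1 gives 3710 nM. Compound 2 `O=C(NC(=S)NNc1ncnc2ccccc12)c1ccc(F)cc1` has the unsubstituted core and a 4-fluorophenyl on the carbonyl; in this assay compound 2 gives 3600 nM. Compound 2 holds the lower of the two numbers, but the gap to compound 1 falls within the usual scatter, so the two values show no separation that can be read as a real difference.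

Compound 3 `Cc1ccccc1C(=O)NC(=S)NNc1ncnc2ccccc12` is the next member and has not yet been measured. It differs from compound 2 in one place: 2-methylphenyl in place of 4-fluorophenyl on a carbonyl carbon. Among the measured compounds shown here, no measured pair isolates this kind of exchange, so there is nothing to calibrate the step against. Compound 3 is therefore expected to land near compound 2, with the step of a 1.1-fold higher number from compound 2 to compound 3 (0.05 log units; within the scatter) expected to stay inside the scatter in either direction. The estimate for compound 3 in this assay is 4000 nM, with a range from 1800 nM to 9000 nM.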

Compound 3, half-maximal inhibitory concentration: 4240 nM
For compound 3 the middle estimate is 1.1-fold (0.03 log units) below the measured one; low and high end bracket the measured number.
By their numbers in this assay, from the lowest: compounds 2, 1 and 3 (each within the scatter of the next).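

In this assay, among the compounds shown here, the exchange of 4-fluorophenyl for 2-methylphenyl on a carbonyl carbon whose other neighbours are an amide-type nitrogen gives a 1.2-fold higher number from compound 2 to compound 3 (0.07 log units; within the scatter) and so provides the first single-place step, one that does not separate the two compounds. The leaving and entering groups have the same heavy-atom count and are each a six-membered aromatic ring of carbon only, and on the unsubstituted core this exchange of a fluorine-bearing ring for a methyl-bearing ring leaves no readable mark on the number. No measurement at hand offers an explanation for this flat step or assigns a property to either group.

On these data alone, whether the flat step extends beyond these two groups remains open: an amine or a carboxylic acid on the ring, or a longer chain in place of the ring, could read differently at this carbonyl carbon. Also open, as far as these compounds go, is whether the same exchange would read the same way on the core of compound 1, which carries two methoxy groups.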